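The source may hold more compounds than are shown below. What is called first, only, known or untested is meant among the compounds shown, and "the series" means these compounds.

In an ADME assay on HEK293 cells (Homo sapiens) for cytotoxicity, with a stated time of 72 h (a higher number here means that more compound is needed for the effect, a lower number that less compound is needed), compound 1 `Cc1cc(NC(=O)Nc2ccccc2C(C)(C)C)c2ccccc2n1` gives > 25000 nM, which is a limit of the assay and not a number. Compound 2 `Cc1cc(NC(=O)Nc2ccccc2C(N)=O)c2ccccc2n1` gives > 25000 nM, again a limit of the assay. Both compounds sit at the limit of > 25000 nM in this assay, at which 2 of the 2 values shown sit, so compound 2 has no readable number to build on.

Compound 3 `COc1ccccc1NC(=O)Nc1cc(C)nc2ccccc12` differs from compound 2 by methoxy in place of carbamoyl on an aromatic carbon. For the measured compounds named here, the one measured step that bears on this change is a step that the two limits leave unreadable from compound 1 to compound 2, so it offers no size to carry over. Going by the values given here, it shows only that compound 1 and compound 2 both stay at the limit in this assay.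

The expected outcome is therefore a number no higher from compound 2 to compound 3 (the limit leaves the size open), with no change beyond the scatter anticipated. For compound 3 the estimate is 25000 nM, with an expected range of 10000 nM to 50000 nM.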

Compound 3, half-maximal effective concentration: > 25000 nM
Compound 3 was reported as a limit; the forecaster's own chance of this, stated with the estimate: 80%; the middle value lies on the limit itself.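

In this assay compound 3 gives > 25000 nM, a limit and not a number. No step among compound 1, compound 2 and compound 3 can be read: the limit of > 25000 nM in this assay, at which 3 of the 3 values shown sit.

The compounds shown leave open whether any group at this aromatic carbon gives a readable number.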